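The source may hold more compounds than are shown below. What is called first, only, known or untested is meant among the compounds shown, and "the series" means these compounds.

In an ADME assay on HuDe cells (Homo sapiens) for cytotoxicity, read by MTT assay, with a stated time of 72 h (a higher number here means a weaker inhibitor, a lower number a stronger inhibitor), compound 1 (`NC(=O)c1ccccc1NC(=O)COc1ccccc1`) gives 523000 nM. Going by the values given here, only one other compound has a measured value so far: compound 2 (`Cc1ccc(OCC(=O)Nc2ccc(I)cc2C(N)=O)cc1`) gives 356000 nM. These two values lie within the usual scatter of each other, so neither compound can be ranked above the other. Among the compounds with values here, compound 2 differs from compound 1 in more than one place, and no measured pair isolates a single structural change.

The compound still awaiting measurement is compound 3 (`Cc1ccc(NC(=O)COc2ccccc2)c(C(N)=O)c1`). It departs from compound 1 in one place: methyl in place of hydrogen on an aromatic carbon. This is methyl in place of hydrogen on an aromatic carbon, meta to a carbamoyl group and para to a large group.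

Within the data shown here, with no measured step to draw on, the only guide is how close the two known values are, and no clear shift in either direction is expected from this small change. The expected result is a 1.2-fold lower number from compound 1 to compound 3 (0.09 log units; within the scatter), a step no larger than the scatter. In this assay, the estimate for compound 3 is 430000 nM, with the value expected to fall between 200000 nM and 850000 nM.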

Compound 3, half-maximal inhibitory concentration: 99300 nM
Compound 3: middle estimate off by 4.3-fold (0.64 log units), on the high side; measured number below the stated range.
By their numbers in this assay, from the lowest: compound 3; then compounds 2 and 1 (each within the scatter of the next).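

In this assay, going by these compounds alone, methyl in place of hydrogen on an aromatic carbon, meta to a carbamoyl group and para to a large group, gives a 5.3-fold lower number from compound 1 to compound 3 (0.72 log units; beyond the scatter), the first measured step in this small set. Within the data shown here, it shows that at this position a change of only one heavy atom, a carbon with no ring, no hydrogen-bond donors or acceptors and no net charge, can move the number beyond the scatter, something the earlier compounds could not show, since compound 1 and compound 2 differ in more than one place. Nothing measured here accounts for the size or direction of this step.

The compounds shown leave open whether the lower number belongs to methyl itself or would also appear with another group in the same place, such as ethyl, methoxy, chlorine or an amine. They also leave open whether a methyl group on any other aromatic carbon of the core of compound 1 would give a comparable step, or none at all.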